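Aryl variation on a shared oxazole ketone core

A few compounds are considered here, and "the series" means these few. Any claim that something is new, unique, unknown or untested is made for them only; others in the source may bear on it.

Measured compounds:
Compound 1, `Nc1cccc(-c2cnc(C(=O)CCCCCCc3ccccc3)o2)c1`: 19 nM
Compound 2, `N#Cc1cccc(-c2cnc(C(=O)CCCCCCc3ccccc3)o2)c1`: 15 nM
Compound 3, `O=C(CCCCCCc1ccccc1)c1ncc(-c2ccc(O)cc2)o1`: 140 nM

All three share one core and differ only in the aryl group attached to it. In an assay (Rattus norvegicus) for inhibition of Fatty-acid amide hydrolase 1 (Homo sapiens) (on this read-out lower numbers stand for stronger inhibition and higher numbers for weaker inhibition), compound 3 gives the highest of the three numbers: a 7.4-fold higher number from compound 1 to compound 3 (0.87 log units; beyond the scatter) and a 9.3-fold higher number from compound 2 to compound 3 (0.97 log units; beyond the scatter), both beyond the scatter. Compound 1 and compound 2 lie within the scatter of each other, a 1.3-fold lower number from compound 1 to compound 2 (0.10 log units; within the scatter), so nothing separates them on this read-out.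

The next compound, compound 4, `NC(=O)c1cccc(-c2cnc(C(=O)CCCCCCc3ccccc3)o2)n1`, is not yet measured in this assay. It differs from compound 3 in one place: 6-carbamoylpyridin-2-yl in place of 4-hydroxyphenyl on an aromatic carbon.

Within the data shown here, no measured step involves a 6-carbamoylpyridin-2-yl group, so no step tells directly what this change does. What the measured steps show is that the 4-hydroxyphenyl of compound 3 gives a higher number than the 3-aminophenyl of compound 1 or the 3-cyanophenyl of compound 2. Leaving 4-hydroxyphenyl for a different aryl is therefore expected to move the number downward, plausibly toward the range of compound 1 and compound 2, but with wide uncertainty because the entering group is unprecedented in the set. The expected step is a 3.1-fold lower number from compound 3 to compound 4 (0.49 log units; beyond the scatter).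

For compound 4 the estimate in this assay is 45 nM, with a range from 10 nM to 250 nM.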

Compound 4, inhibition constant: 1 nM
Compound 4: middle estimate off by 45-fold (1.65 log units), on the high side; measured number below the stated range.
By their numbers in this assay, from the lowest: compound 4; then compounds 2 and 1 (each within the scatter of the next); then compound 3.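

In this assay the aryl position next to the ring oxygen of the shared core proves far more sensitive than the first three compounds suggested: 6-carbamoylpyridin-2-yl in place of 4-hydroxyphenyl gives a 140-fold lower number from compound 3 to compound 4 (2.15 log units; beyond the scatter) and exceeds every earlier step. The same group also goes well past the two lower earlier numbers, with a 15-fold lower number from compound 2 to compound 4 (1.18 log units; beyond the scatter) against 3-cyanophenyl and a 19-fold lower number from compound 1 to compound 4 (1.28 log units; beyond the scatter) against 3-aminophenyl, so the level shared by those two compounds is not the floor for this position. Nothing among the available data speaks to what lies behind these steps.

The entering group brings a ring nitrogen and a carbamoyl together, and the compounds shown do not separate the two; a plain pyridin-2-yl and a 3-carbamoylphenyl would divide the step between them. Also open, on these data alone, is whether a carboxylic acid or a methyl ester can stand in for the carbamoyl, and whether the gain survives on a shorter chain than the one shared by all four compounds.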